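Trimming a methoxymethoxy group in a chromone series

The source may report more compounds than this note shows. Statements on the series, on what has been measured and on what is new or still open speak of the compounds shown alone.

Compound 1 `COCOc1cc(O)c2c(=O)cc(C3(O)C=CC(=O)C=C3)oc2c1` gives 15600 nM in a functional assay on HepG2 cells (Homo sapiens) for cytotoxicity, read by colorimetric assay and MTT assay, with a stated time of 72 h; a lower number here means a stronger inhibitor, a higher number a weaker inhibitor.
Compound 2 `O=C1C=CC(O)(c2cc(=O)c3ccccc3o2)C=C1` gives 6730 nM in this assay.

Compound 1 stands at the higher of the two numbers, and its gap to compound 2 lies beyond the scatter, so compound 1 is the weaker inhibitor of the pair. The unmeasured compound 3 `COc1cc(O)c2c(=O)cc(C3(O)C=CC(=O)C=C3)oc2c1` keeps the core of compound 1 and differs in one place: hydrogen in place of methoxy on a saturated chain carbon bound to an oxygen on an aromatic ring. Among the compounds with values here, no measured pair shows this exact change, so its effect can only be guessed from the two values at hand. The step from compound 1 to compound 3 is expected to be small, most likely toward a somewhat lower number, though a result within the scatter would not surprise. The expected step is a 1.6-fold lower number from compound 1 to compound 3 (0.19 log units; within the scatter). Compound 3 is therefore estimated at 10000 nM, with a range from 4000 nM to 30000 nM.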

Compound 3, half-maximal inhibitory concentration: 570 nM
Estimate against measurement, compound 3: 18-fold (1.24 log units) above; the measured number lies below the stated range.
By their numbers in this assay, from the lowest: compound 3; then compound 2; then compound 1.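

Trimming methoxymethoxy to methoxy is far from a neutral change: in this assay it gives a 27-fold lower number from compound 1 to compound 3 (1.44 log units; beyond the scatter), a large step well beyond the scatter. Within the data shown here, this pair gives the first direct reading of the position, showing that removing a methoxy group, with its two heavy atoms and one hydrogen-bond acceptor, from a saturated chain carbon bound to an oxygen on an aromatic ring can strongly shift the number on its own while the rest of the core of compound 1 stays the same. Nothing at hand gives a measured reason for the size of this step.

From the compounds shown here alone, with a single pair reading this position, it remains open whether the trend extends to other groups. An ethoxy group or an amine in the same place could show how closely the number follows the group's identity.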